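This account rests on a few compounds, and the source may have more. Where it says the series, first, only, none or still open, it means among the compounds named here.

In a functional assay on HCT-116 cells (Homo sapiens), read by MTT assay, with a stated time of 72 h (a lower number here means a stronger inhibitor, a higher number a weaker inhibitor), compound 3 (`COc1nc(N)nc2c1c(-c1cccs1)cn2[C@@H]1O[C@H](CO)[C@@H](O)[C@H]1O`) gives > 20000 nM as a limit of the assay and not a number. Compound 2 (`COc1nc(N)nc2c1c(-c1ccoc1)cn2[C@@H]1O[C@H](CO)[C@@H](O)[C@H]1O`) likewise gives > 20000 nM as a limit. Within the data shown here, these two compounds therefore share the limit of > 20000 nM in this assay, at which 2 of the 3 values shown sit, as their only reading. Among the measured compounds shown here, the one measured step is a step that the two limits leave unreadable from compound 2 to compound 3 and offers no size to carry forward.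

The change to compound 4 (`C#Cc1cn([C@@H]2O[C@H](CO)[C@@H](O)[C@H]2O)c2nc(N)nc(OC)c12`) is ethynyl in place of thiophen-2-yl on an aromatic carbon. For the measured compounds named here, no measured step covers this exchange directly. The nearest evidence is compound 1 (`C#Cc1cn([C@@H]2O[C@H](CO)[C@@H](O)[C@H]2O)c2ncnc(OC)c12`), which also bears ethynyl and gives 4060 nM as a true number in this assay rather than a limit. It is a single value and not a step, so it can only suggest a direction. Going by the values given here, on the strength of compound 1 at 4060 nM as the sole ethynyl reading, a move toward stronger inhibition is expected, of uncertain size. A result that stays at the limit remains a real possibility. The expected change is an at least 2.2-fold lower number from compound 3 to compound 4 (0.34 log units; beyond the scatter) in the direction of stronger inhibition. Compound 4 is estimated at 9000 nM (expected range 2500 nM to 20000 nM).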

Compound 4, half-maximal inhibitory concentration: > 20000 nM
Compound 4 gave a limit, no number (the forecaster's own chance of this, stated with the estimate: 35%); at least 2.2-fold (0.34 log units) between middle value and limit.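

With ethynyl on this aromatic carbon, compound 4 still reads in this assay only as a limit of the assay and not a number, so this small group with no ring does not lift the amino-bearing core off that limit: the limit of > 20000 nM in this assay, at which 3 of the 4 values shown sit. The steps to compound 4 from compound 2 and compound 3 cannot be read, which leaves ethynyl in place of thiophen-2-yl or furan-3-yl without a size. Among these compounds, the one readable comparison concerns a different change, with ethynyl held fixed: amino in place of hydrogen on an aromatic carbon gives an at least 4.9-fold higher number from compound 1 to compound 4 (0.69 log units; beyond the scatter), so within this pair the weaker reading goes with the amino group.

As far as these compounds go, it remains open whether any group at this position, such as an aminomethyl group or a carboxylic acid, brings an amino-bearing compound to a true number in this assay. Also open, from the compounds shown here alone, is how thiophen-2-yl or furan-3-yl would read on the core of compound 1, which carries no amino group, and whether that pairing would give the exchange at this position a measurable size.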